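From 4-methylthiophen-2-yl to 5-methylthiophen-2-yl

The source may hold more compounds than are shown below. What is called first, only, known or untested is meant among the compounds shown, and "the series" means these compounds.

Measured in a functional assay on HUVEC cells (Homo sapiens), read by BrdU incorporation, with a stated time of 72 h (a higher number here means a weaker inhibitor, a lower number a stronger inhibitor), so far:
- compound 1 `Cc1ccc2nc(Cl)c(/C=C/C(=O)c3ccc(Cl)s3)cc2c1` gives 59.4 nM
- compound 2 `Cc1csc(C(=O)/C=C/c2cc3cc(C)ccc3nc2Cl)c1` gives 106 nM

In this assay compound 2 stands within the scatter of compound 1, so the two cannot be ranked. Compound 3 `Cc1ccc2nc(Cl)c(/C=C/C(=O)c3ccc(C)s3)cc2c1` differs from compound 2 by one change (5-methylthiophen-2-yl in place of 4-methylthiophen-2-yl on a carbonyl carbon). Within the data shown here, only one measured step bears on it, the exchange of 5-chlorothiophen-2-yl for 4-methylthiophen-2-yl on the carbonyl carbon (a 1.8-fold higher number from compound 1 to compound 2 (0.25 log units; within the scatter)). On that evidence, no step beyond the scatter is expected (a 1.3-fold lower number from compound 2 to compound 3 (0.12 log units; within the scatter)). The expected value for compound 3 is 80 nM, with an estimated range from 35 nM to 180 nM.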

Compound 3, half-maximal inhibitory concentration: 128 nM
For compound 3 the middle estimate is 1.6-fold (0.20 log units) below the measured one; measured number inside the range.
By their numbers in this assay, from the lowest: compounds 1, 2 and 3 (each within the scatter of the next, the first and the last beyond it).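

In this assay, the methyl group can sit in either named thiophene position without a readable difference (a 1.2-fold higher number from compound 2 to compound 3 (0.08 log units; within the scatter)). Among these compounds, the change of 5-chlorothiophen-2-yl to 5-methylthiophen-2-yl, methyl in place of chloro on an aromatic carbon, gives the first step beyond the scatter (a 2.2-fold higher number from compound 1 to compound 3 (0.33 log units; beyond the scatter)), though only a modest one. No available measurement accounts for either step.

The compounds shown leave open how a 5-aminothiophen-2-yl or 5-methoxythiophen-2-yl group on the carbonyl carbon would read. They also leave open whether a phenyl group could stand in place of the thiophene.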